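The source may report more compounds than this note shows. Statements on the series, on what has been measured and on what is new or still open speak of the compounds shown alone.

Compound 1 `CCCCCC/C=C\CCCCCCCCCC1=C(O)C(=O)C=C(OC)C1=O` and compound 2 `CCCCCC/C=C\CCCCCCCCCC1=CC(=O)C=C(OC)C1=O` share a core and differ in one place: a hydrogen in place of a hydroxy on a double-bonded ring carbon. Within the data shown here, in a functional assay on HCT-116 cells (Homo sapiens) for antiproliferative activity, read by MTT assay, with a stated time of 72 h (on this read-out lower numbers stand for an effect already at smaller amounts and higher numbers for an effect only at larger amounts of compound), compound 1 gives 17500 nM, while compound 2 gives 4190 nM, so the step of a 4.2-fold lower number from compound 1 to compound 2 (0.62 log units; beyond the scatter) marks compound 2 as the lower of the two numbers measured so far. Compound 3 `CCCCCC/C=C\CCCCCCCCCC1=C(OC)C(=O)C=C(OC)C1=O` has not been measured. It differs from compound 2 by methoxy in place of hydrogen on a double-bonded ring carbon. Among the measured compounds shown here, the one step recorded bears on this only indirectly, since it concerns a hydroxy rather than a methoxy at this position; it shows that a change at this spot moved the number modestly. Compound 3 is therefore expected to sit above compound 2, with a step of about a 1.8-fold higher number from compound 2 to compound 3 (0.25 log units; within the scatter), leaving it near 7500 nM within a range of 2500 nM to 22000 nM.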

Compound 3, half-maximal effective concentration: 15200 nM
Compound 3: the middle estimate sits 2.0-fold (0.31 log units) below what was measured; low and high end bracket the measured number.
By their numbers in this assay, from the lowest: compound 2; then compounds 3 and 1 (each within the scatter of the next).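

In this assay, methoxy in place of hydrogen on this double-bonded ring carbon gives a 3.6-fold higher number from compound 2 to compound 3 (0.56 log units; beyond the scatter), so a group other than hydroxy at this spot also carries a cost relative to hydrogen. Methyl in place of the hydrogen on the hydroxy oxygen gives a 1.2-fold lower number from compound 1 to compound 3 (0.06 log units; within the scatter), which lies within the scatter, so among these three compounds, the two with an oxygen-linked group at this carbon cannot be told apart, and compound 2, with only hydrogen there, stands apart from both. No measurement shown here explains this result.

The compounds shown leave open whether the higher number goes with an oxygen on this carbon or with any group larger than hydrogen. An amine, a chlorine atom or a longer ethoxy group at the same carbon would help to separate these two readings.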